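Lengthening the acyl group on a potent amide

This account rests on a few compounds, and the source may have more. Where it says the series, first, only, none or still open, it means among the compounds named here.

Measured compounds:
- compound 1, `COc1ccc(CN(C(C)=O)c2cc(OC)c(OC)c(OC)c2)cc1O`, gives 79 nM in a functional assay on MGC-803 cells (Homo sapiens) for inhibition, read by MTT assay, with a stated time of 48 h; a higher number here means a weaker inhibitor, a lower number a stronger inhibitor
- compound 2, `C/C=C/C(=O)N(Cc1cc(OC)c(OC)c(OC)c1)c1ccc(OC)c(O)c1`, gives 6150 nM in this assay
- compound 3, `C/C=C/C(=O)N(Cc1ccc(OC)c(OC)c1)c1cc(OC)c(OC)c(OC)c1`, gives 20100 nM in this assay

Compound 1 has the lowest number of the three in this assay, meaning it is the strongest inhibitor among them; compound 2 and compound 3 sit far higher, well beyond the usual scatter. Compound 2 and compound 3 differ from compound 1 in more than one place, so nothing can be read from them about any single change.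

Compound 4, `CCC(=O)N(Cc1ccc(OC)c(O)c1)c1cc(OC)c(OC)c(OC)c1`, has not yet been measured in this assay. It differs from compound 1 in only one spot: methyl in place of hydrogen on a saturated chain carbon bound to a carbonyl carbon. Read one bond further out, this is methyl to ethyl, or acetyl to propanoyl.

Among the measured compounds shown here, no measured pair shows the effect of this change on its own. Because compound 1 gives 79 nM and the change adds only one carbon to a short chain, a small step, if any, is expected, with a slight lean toward a weaker inhibitor: the expected step is a 1.9-fold higher number from compound 1 to compound 4 (0.28 log units; within the scatter). Compound 4 is therefore estimated at 150 nM, within a range of 40 nM to 600 nM.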

Compound 4, half-maximal inhibitory concentration: 50 nM
Compound 4: middle estimate off by 3.0-fold (0.48 log units), on the high side; the range from low to high includes it.
By their numbers in this assay, from the lowest: compounds 4 and 1 (each within the scatter of the next); then compound 2; then compound 3.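

In this assay, methyl in place of hydrogen on a saturated chain carbon bound to a carbonyl carbon gives a 1.6-fold lower number from compound 1 to compound 4 (0.20 log units; within the scatter), so acetyl and propanoyl cannot be told apart here. Among the compounds shown here, this is the first direct reading at this position, and it shows that the acyl group of compound 1 can take this one added carbon with the number staying within the scatter. The data at hand offer no measured explanation for this result.

From the compounds shown here alone, only this single extension can be read, so it remains open whether a longer chain such as butanoyl would also stay in this range. A cyclopropyl ring or an amine at the same place is likewise untested among the compounds shown, so how far this position accepts other groups cannot be said.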